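The source may hold more compounds than are shown below. What is called first, only, known or untested is meant among the compounds shown, and "the series" means these compounds.

In an assay on isolated protein for inhibition of geranylgeranyl pyrophosphate synthase (Homo sapiens), tested at 100 uM (on this read-out lower numbers stand for less inhibition and higher numbers for more inhibition at the one concentration tested (going by the name of the read-out)), compound 2 `CCOC(=O)/C=C/c1ccc(OC/C=C(\C)CCC=C(C)C)c(O)c1` gives -7.4%, and compound 1 `CCOC(=O)/C=C/c1ccc(OC/C=C(\C)CCC=C(C)C)c(OC)c1` gives 5.5%. The two differ only by methyl in place of hydrogen on an oxygen on an aromatic ring, and that change made a step of a number 12.9 percentage points higher from compound 2 to compound 1 (beyond the scatter). Compound 3 `CC(C)=CCOc1ccc(C(=O)O)cc1O` gives 0% in this assay; how its core differs from that of compound 2 is not broken down here. Compound 4 `COc1cc(C(=O)O)ccc1OCC=C(C)C` has not yet been measured. It differs from compound 3 by methyl in place of hydrogen on an oxygen on an aromatic ring, the same change as between compound 2 and compound 1, made at the same kind of place. On the strength of the earlier step of a number 12.9 percentage points higher from compound 2 to compound 1 (beyond the scatter), compound 4 is expected to show a step of a number 7 percentage points higher from compound 3 to compound 4 (within the scatter), though compound 3 already sits close to compound 1, whose value is 5.5%. The estimate for compound 4 is therefore 7%, between -8% and 22%.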

Compound 4, a percentage reported as inhibition, at one concentration (the size of the read-out at that concentration, not a potency): 2.4%
Compound 4: middle estimate off by 4.6 percentage points, on the high side; low and high end bracket the measured number.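

In this assay, methyl in place of hydrogen on an oxygen on an aromatic ring made a step of a number 2.4 percentage points higher from compound 3 to compound 4 (within the scatter). Set beside the same change on the other core, the two steps cannot be told apart: the same change on two cores in this assay, a number 12.9 percentage points higher (beyond the scatter) from compound 2 to compound 1 and a number 2.4 percentage points higher (within the scatter) from compound 3 to compound 4, 10.5 percentage points apart, within the scatter of two such steps This shows that the change behaves compatibly on these two cores, but it does not show that the step has one fixed size or that it would carry to any further core, since only two cores are compared.

The compounds shown leave open what a longer chain than methyl on that oxygen would do. They also leave open how an amide in place of the carboxylic acid of compound 4 would read.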